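Series notes: compounds 1 to 4, replacement at the oxygen-bound group

The source may hold more compounds than are shown below. What is called first, only, known or untested is meant among the compounds shown, and "the series" means these compounds.

The shared core carries a naphthyloxyacetyl group, a valine unit and an aspartate unit ending in a ketone with a substituted methylene. Compound 1 `CC(C)[C@H](NC(=O)COc1cccc2ccccc12)C(=O)N[C@@H](CC(=O)O)C(=O)CSc1nc[nH]n1` bears a 1H-1,2,4-triazol-3-yl on a sulfur. In a functional assay on Jurkat cells (Homo sapiens) for inhibition (on this read-out higher numbers stand for weaker inhibition and lower numbers for stronger inhibition), compound 1 returns only a limit, > 200000 nM. Compound 2 `CC(C)[C@H](NC(=O)COc1cccc2ccccc12)C(=O)N[C@@H](CC(=O)O)C(=O)CSc1nc2ccccc2[nH]1` has 1H-benzimidazol-2-yl in place of 1H-1,2,4-triazol-3-yl on the sulfur. In this assay compound 2 also returns only a limit, > 200000 nM. Compound 3 `CC(C)[C@H](NC(=O)COc1cccc2ccccc12)C(=O)N[C@@H](CC(=O)O)C(=O)COn1nnc2ccccc21` carries a benzotriazolyl-type group on an oxygen instead of the sulfur-linked ring. In this assay compound 3 gives a limit as well, > 200000 nM. Compound 3 therefore stands where every other measured compound stands, at the limit of > 200000 nM in this assay, at which 3 of the 3 values shown sit.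

The measured steps are a step that the two limits leave unreadable from compound 1 to compound 2, a step that the two limits leave unreadable from compound 1 to compound 3 and a step that the two limits leave unreadable from compound 2 to compound 3; none of them can be sized, since both ends of each step sit at the limit.

Compound 4 `CC(C)[C@H](NC(=O)COc1cccc2ccccc12)C(=O)N[C@@H](CC(=O)O)C(=O)COn1nnc2ccccc2c1=O` is not yet measured. It differs from compound 3 thus: a group of 11 heavy atoms (7 carbon, 3 nitrogen, 1 oxygen; one six-membered aromatic ring of carbon only, one six-membered aromatic ring with 3 hetero atoms) in place of a group of 9 heavy atoms (6 carbon, 3 nitrogen; one five-membered aromatic ring with 3 hetero atoms, one six-membered aromatic ring of carbon only), on an oxygen on a saturated carbon. No measured step bears on this change in a readable way, and nothing in the numbers shown separates any of compounds 1, 2 and 3 from one another. The step of a number no higher from compound 3 to compound 4 (the limit leaves the size open) is therefore expected to show none beyond the scatter, most likely another limit. Compound 4 is estimated at 200000 nM, in a range from 50000 nM to 400000 nM.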

Compound 4, half-maximal inhibitory concentration: 137000 nM
For compound 4 the middle estimate is 1.5-fold (0.16 log units) above the measured one, and the stated range covers the measured number.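

Within the data shown here, compound 4, with the group of 11 heavy atoms on an oxygen on a saturated carbon, is the only compound of the four with a number rather than a limit in this assay, which gives an at least 1.4-fold lower number from compound 3 to compound 4 (0.16 log units; that floor lies within the scatter). The comparisons with the sulfur-linked groups read the same way, with an at least 1.4-fold lower number from compound 2 to compound 4 (0.16 log units; that floor lies within the scatter) and an at least 1.4-fold lower number from compound 1 to compound 4 (0.16 log units; that floor lies within the scatter). Each of these floors lies within the scatter, so the change gives the series a readable value but does not establish a real gain in inhibition, and the other compounds remain at a limit: the limit of > 200000 nM in this assay, at which 3 of the 4 values shown sit.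

From the compounds shown here alone, the true size of all three steps remains open, as the limits give only floors and no upper bound on any of them. Going by these compounds, it also remains open whether a phenyl ring or a carboxylic acid on an oxygen on a saturated carbon would give a number in this assay or return to the limit.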